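Replacing Cyano in a Series of Level Values

This account rests on a few compounds, and the source may have more. Where it says the series, first, only, none or still open, it means among the compounds named here.

Compound 1 `COc1ccc2cc(-c3ccccc3)c(O)nc2c1` (10000 nM)
Compound 2 `COc1cc(OC)c2cc(-c3ccc(OCc4ccccc4)cc3)c(O)nc2c1` (10000 nM)
Compound 3 `COc1ccc(-c2cc3c(OC)cc(OC)cc3n(CC#N)c2=O)cc1` (10000 nM)

All three compounds were tested in a functional assay on A 172 cells (Homo sapiens) for cytotoxicity, read by colorimetric assay and MTT assay; a lower number here means a stronger inhibitor, a higher number a weaker inhibitor. Compound 3 (10000 nM) stands level with compound 1 (10000 nM) and compound 2 (10000 nM), with nothing to separate the three at the digits reported. Their structures differ in several places, yet the readings coincide. For the measured compounds named here, no measured pair differs in one place only, so the data offer no direct guide to the effect of a single change.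

The next compound, compound 4 `COC(=O)CCn1c(=O)c(-c2ccc(OC)cc2)cc2c(OC)cc(OC)cc21`, has not yet been measured. Its difference from compound 3 is (methoxycarbonyl)methyl in place of cyano on a saturated chain carbon bound to an aromatic nitrogen. In words, (methoxycarbonyl)methyl stands in place of cyano on a saturated chain carbon bound to an aromatic nitrogen, and the same difference, cut one bond further out, reads cyanomethyl to 2-(methoxycarbonyl)ethyl.

The expectation rests on compound 3 at 10000 nM and on the matching readings of the two other measured compounds. No step beyond the scatter is expected in this assay, and so no direction is predicted. The estimated change is no change at the digits printed from compound 3 to compound 4 (within the scatter). For compound 4 the estimated value is 10000 nM, with an expected range from 4000 nM to 15000 nM.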

Compound 4, half-maximal inhibitory concentration: 10000 nM
Beside the measured number, compound 4's estimate shows no gap at the digits printed, within the range that was stated.
By their numbers in this assay, from the lowest: compounds 1, 2, 3 and 4 (each within the scatter of the next).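

In this assay, for the compounds shown here, the change of cyanomethyl to 2-(methoxycarbonyl)ethyl gives the first step that can be read between compounds differing in one place: no change at the digits printed from compound 3 to compound 4 (within the scatter). At this position, on a saturated chain carbon bound to an aromatic nitrogen, (methoxycarbonyl)methyl can therefore stand in place of cyano without a reading that can be told apart, even though it brings more heavy atoms, a double bond outside aromatic rings and one more hydrogen-bond acceptor. No measured property is at hand that would account for this result.

The compounds shown leave open whether a carboxylic acid, an amine or a longer chain in the same place would separate from compound 3 in this assay, since this single step samples only one replacement. They also leave open whether any change on the shared core would move the reading, as the other compounds differ from compound 3 in several places and so offer no comparison of that kind.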